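Methyl in Place of Chloro: From Compound 2 to Compound 4

The source may report more compounds than this note shows. Statements on the series, on what has been measured and on what is new or still open speak of the compounds shown alone.

Measured compounds:
- Compound 1, `COc1cccc(/C=C/C(=O)c2sc(Nc3ccc(Cl)cc3)nc2C)c1`: > 25000 nM (a limit of the assay, not a number)
- Compound 2, `COc1cc(/C=C/C(=O)c2sc(Nc3ccc(Cl)cc3)nc2C)cc(OC)c1OC`: 22000 nM
- Compound 3, `Cc1cccc(Nc2nc(C)c(C(=O)/C=C/c3ccccc3)s2)c1`: 21800 nM

All three were tested in a functional assay on NCI-H460 cells (Homo sapiens) for cytotoxicity, read by MTT assay; a lower number here means a stronger inhibitor, a higher number a weaker inhibitor. Compound 2 gives 22000 nM in this assay. Compound 3 gives 21800 nM, and the two numbers lie within the scatter of each other, so neither can be called stronger or weaker than the other. For compound 1 the assay reports only a limit, (the limit of > 25000 nM in this assay, at which 1 of the 3 values shown sits), and no number.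

The step studied here leads to compound 4, `COc1cc(/C=C/C(=O)c2sc(Nc3ccc(C)cc3)nc2C)cc(OC)c1OC`, which has not yet been measured. It differs from compound 2 in one place: methyl in place of chloro on an aromatic carbon. The rest of the shared core, including the three methoxy groups and the enone linker, is unchanged.

Within the data shown here, no pair of measured compounds shows the effect of this exchange, so there is no measured step to lean on. With a single small group swapped for another small group on the same aromatic carbon, the expectation is no shift beyond the usual scatter, in either direction. For compound 4 the estimate is therefore 25000 nM, with a range from 11000 nM to 60000 nM. The expected step is a 1.1-fold higher number from compound 2 to compound 4 (0.06 log units; within the scatter).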

Compound 4, half-maximal inhibitory concentration: > 25000 nM
Compound 4 ended at the assay's limit; the forecaster's own chance of this, stated with the estimate: 45%; the middle value lies on the limit itself.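

Chloro and methyl are both small groups of one heavy atom, and the earlier compounds offered no pair showing what exchanging them on this aromatic carbon does. In this assay the exchange now reads an at least 1.1-fold higher number from compound 2 to compound 4 (0.05 log units; that floor lies within the scatter), and this is a floor rather than the true size of the step. Compound 4 gives > 25000 nM, which is a limit of the assay and not a number, so 4-methylphenyl in place of 4-chlorophenyl brings no measurable gain in strength, and the readings at this position stay close to the top of what the assay can report: the limit of > 25000 nM in this assay, at which 2 of the 4 values shown sit.

Still open, as far as these compounds go, is how far the true value for compound 4 lies from the number for compound 2, and whether that gap goes beyond the usual scatter or stays within it. Also open, from the compounds shown here alone, is how this assay would respond to an amine, a hydroxyl group or a longer chain such as propyl on the same aromatic carbon, with the rest of the shared core unchanged.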